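Fluoro on the aromatic ring of compound 3

A few compounds are considered here, and "the series" means these few. Any claim that something is new, unique, unknown or untested is made for them only; others in the source may bear on it.

Compound 1 `Nc1ccccc1NC(=O)CCCCCCc1nc(-c2ccccc2)no1`: 960 nM
Compound 2 `Nc1ccccc1NC(=O)CCCCCCc1nc(-c2ccc([N+](=O)[O-])cc2)no1`: > 100000 nM (a limit of the assay)
Compound 3 `O=C(CCCCCCc1nc(-c2ccccc2)no1)C(F)(F)F`: 520 nM

In a functional assay on NCI-H661 cells (Homo sapiens) for antiproliferative activity, read by MTT assay, with a stated time of 72 h (on this read-out higher numbers stand for weaker inhibition and lower numbers for stronger inhibition), compound 3 gives 520 nM and stands within the scatter of compound 1, as a 1.8-fold lower number from compound 1 to compound 3 (0.27 log units; within the scatter) shows. That step concerns the group on a carbonyl carbon, not the aromatic ring. Compound 4 `O=C(CCCCCCc1nc(-c2ccc(F)cc2)no1)C(F)(F)F` carries fluoro in place of hydrogen on an aromatic carbon, para to a large group: fluoro in place of hydrogen on an aromatic carbon. Going by the values given here, the only measured step on that ring is an at least 100-fold higher number from compound 1 to compound 2 (2.01 log units; beyond the scatter), which is large, but it brings in nitro rather than fluoro and ends at a limit. It gives a caution, so the range expected here is kept wide on the upper side. The expected step is a 1.3-fold higher number from compound 3 to compound 4 (0.13 log units; within the scatter), with no shift beyond the scatter. For compound 4 the estimated value is 700 nM, with an expected range from 180 nM to 5000 nM.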

Compound 4, half-maximal inhibitory concentration: 12700 nM
Estimate against measurement, compound 4: 18-fold (1.26 log units) below; the whole stated range lies below it.
By their numbers in this assay, from the lowest: compounds 3 and 1 (each within the scatter of the next); then compound 4. At a limit, above all of these: compound 2.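

In this assay a single fluoro on this aromatic carbon gives a 24-fold higher number from compound 3 to compound 4 (1.39 log units; beyond the scatter) and so shows that even this one-atom change at the place para to a large group is not neutral. Nitro at this place gave an at least 100-fold higher number from compound 1 to compound 2 (2.01 log units; beyond the scatter) and ended at a limit, whereas the fluoro step is a large rise with a measured value, on a different group at the carbonyl carbon. No measurement shown gives a cause for this step. The compounds shown leave open whether an amine or a methoxy group here would also raise the number. They also leave open how fluoro would behave with the (2-aminophenyl)amino group on the carbonyl carbon.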